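Swapping the furan arm for a hydroxy-methoxyphenyl arm

The source may report more compounds than this note shows. Statements on the series, on what has been measured and on what is new or still open speak of the compounds shown alone.

Measured compounds:
- compound 1, `COc1cccc(CNCCCNc2ccnc3cc(Oc4ccccc4)ccc23)c1O`: 14500 nM
- compound 2, `COc1cccc(CNCCCNc2ccnc3cc(Cc4ccc(C#N)cc4)ccc23)c1O`: 4200 nM
- compound 3, `c1coc(CNCCCNc2ccnc3cc(C4CCCCC4)ccc23)c1`: 4200 nM

All three were run in a physicochemical assay for solubility, with a stated time of 18 h, at pH 7.4; on this read-out lower numbers stand for lower solubility and higher numbers for higher solubility. Compound 3 stands level with compound 2 at the digits shown, and compound 1 sits above both; compound 1 to compound 3 is a step of the same size as a 3.5-fold lower number from compound 1 to compound 2 (0.54 log units; beyond the scatter), and that step came from a change on the shared core, 4-cyanobenzyl in place of phenoxy on an aromatic carbon.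

Compound 4, `COc1cccc(CNCCCNc2ccnc3cc(C4CCCCC4)ccc23)c1O`, keeps the core of compound 3 and changes only the arm on the amine: 2-hydroxy-3-methoxyphenyl in place of furan-2-yl on a saturated chain carbon bound to an amine nitrogen. Among the measured compounds shown here, no measured pair shows this exact change, so the one step that exists does not bear on it directly. What can be said is that compounds 1 and 2 already carry the entering arm, and compound 2 gives the same number as compound 3 even though the two differ in more than one place. On that ground a step of no real size is expected, no change at the digits printed from compound 3 to compound 4 (within the scatter), with a wide band to allow for the untested change. Compound 4 is therefore estimated at 4200 nM, between 1500 nM and 12000 nM.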

Compound 4, solubility: 4200 nM
Compound 4: middle estimate and measured number agree at the digits printed, and the stated range covers the measured number.
By their numbers in this assay, from the lowest: compounds 2, 3 and 4 (each within the scatter of the next); then compound 1.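

In this assay the arm on the amine can now be read directly: 2-hydroxy-3-methoxyphenyl in place of furan-2-yl on a saturated chain carbon bound to an amine nitrogen gives no change at the digits printed from compound 3 to compound 4 (within the scatter). The swap is not a small one on paper, since it brings 9 heavy atoms in place of 5 and 1 hydrogen-bond donor in place of 0, yet this core with cyclohexyl tolerates it without a shift in the read-out. With the new arm held fixed, the group on the aromatic carbon can also be compared in single changes: cyclohexyl in place of 4-cyanobenzyl gives no change at the digits printed from compound 2 to compound 4 (within the scatter) and cyclohexyl in place of phenoxy gives a 3.5-fold lower number from compound 1 to compound 4 (0.54 log units; beyond the scatter), so among these three compounds only the phenoxy compound stands apart.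

No supporting measurement accounts for either the flat step or the phenoxy gap. Still open, on these data alone, is whether the arm swap stays this quiet with phenoxy or 4-cyanobenzyl on the shared core, and how a carboxylic acid or a morpholine on that aromatic carbon, or a longer chain on the amine side, would read.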